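The source may hold more compounds than are shown below. What is called first, only, known or untested is meant among the compounds shown, and "the series" means these compounds.

In an ADME assay on WI-38 cells (Homo sapiens) for cytotoxicity, read by MTT assay, with a stated time of 72 h (a lower number here means a stronger inhibitor, a higher number a weaker inhibitor), compound 1 `CC(C)c1cccc(NC(=O)CCc2cccc3c2B(O)OC3)c1` gives 22000 nM, while compound 2 `CSc1cccc(-c2cccc(NC(=O)CCc3cccc4c3B(O)OC4)c2)c1` gives 2000 nM, the lower of the two numbers. Within the data shown here, the only measured step, an 11-fold lower number from compound 1 to compound 2 (1.04 log units; beyond the scatter), came with 3-(methylsulfanyl)phenyl in place of isopropyl on an aromatic carbon. Compound 3 `O=C(CCc1cccc2c1B(O)OC2)Nc1cccc(-c2cccc(C(F)(F)F)c2)c1` makes a smaller change: trifluoromethyl in place of methylsulfanyl on an aromatic carbon, with trifluoromethyl in place of methylsulfanyl on an aromatic carbon. Among the measured compounds shown here, no measured step covers this swap, so the expectation starts from compound 2 at 2000 nM and foresees no shift beyond the scatter in this assay. The expected step is a 1.3-fold higher number from compound 2 to compound 3 (0.10 log units; within the scatter). Compound 3 is estimated at 2500 nM, with a range of 900 nM to 7000 nM.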

Compound 3, half-maximal inhibitory concentration: 23000 nM
The estimate for compound 3 lay 9.2-fold (0.96 log units) below the measured number, and the stated range ends below it.
By their numbers in this assay, from the lowest: compound 2; then compounds 1 and 3 (each within the scatter of the next).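

In this assay, the outer group decides the result: trifluoromethyl in place of methylsulfanyl on an aromatic carbon gives (a 12-fold higher number from compound 2 to compound 3 (1.06 log units; beyond the scatter)), so the extra phenyl ring alone does not carry the lower number of compound 2. With 3-(trifluoromethyl)phenyl in place of isopropyl, the values cannot be told apart (a 1.0-fold higher number from compound 1 to compound 3 (0.02 log units; within the scatter)). Nothing available explains why these two groups differ so much. Open, as far as these compounds go, is where an amine or a carboxylic acid at this same place would fall, and whether a longer sulfur chain such as ethylsulfanyl would match compound 2.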